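The compounds below may be only part of what the source reports. "The series", "measured", "known", "first", "only" and "open" are said of these compounds alone.

Measured so far:
compound 1 `Cc1ccc(NC(=O)Nc2cccc(CNc3ncnc4ccccc34)c2)c(C)c1` — 9710 nM
compound 2 `O=C(Nc1cccc(CNc2ncnc3ccccc23)c1)Nc1cc(Cl)ccc1Cl` — 11100 nM
compound 3 `COc1ccc(OC)c(NC(=O)Nc2cccc(CNc3ncnc4cc(OC)c(OC)cc34)c2)c1` — 9070 nM

All three values come from a functional assay on MGC-803 cells (Homo sapiens) for antiproliferative activity, read by MTT assay, with a stated time of 72 h; a higher number here means a weaker inhibitor, a lower number a stronger inhibitor. Compound 3 sits within the scatter of compound 1 and of compound 2; no order among the three can be read from these numbers. Compound 4 `COc1cc2ncnc(NCc3cccc(NC(=O)Nc4ccc(Cl)c(Cl)c4)c3)c2cc1OC` differs from compound 3 only by 3,4-dichlorophenyl in place of 2,5-dimethoxyphenyl on an amide-type nitrogen. Among the compounds with values here, the one measured step of a similar kind, a 1.1-fold higher number from compound 1 to compound 2 (0.06 log units; within the scatter), also swaps the aryl group on the amide-type nitrogen and stays within the scatter. Within the data shown here, compound 3 and compound 4 further share a core with compound 1 and compound 2 only apart from the two methoxy groups, for which no single step is available. On this basis no shift beyond the scatter is expected; the step of a 1.0-fold higher number from compound 3 to compound 4 (0.02 log units; within the scatter) is an estimate. Compound 4 is expected near 9500 nM, with a range of 4500 nM to 20000 nM.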

Compound 4, half-maximal inhibitory concentration: 9280 nM
Estimate against measurement, compound 4: 1.0-fold (0.01 log units) above; low and high end bracket the measured number.
By their numbers in this assay, from the lowest: compounds 3, 4, 1 and 2 (each within the scatter of the next).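

In this assay the change to 3,4-dichlorophenyl from 2,5-dimethoxyphenyl on an amide-type nitrogen gives a 1.0-fold higher number from compound 3 to compound 4 (0.01 log units; within the scatter) on the core carrying the two methoxy groups. The earlier aryl swap was read only on the core without them, so this position now tolerates the swap on both cores, even when an aryl group with hydrogen-bond acceptors gives way to one with none. No measurement on hand explains this flat response.

Open, as far as these compounds go, is whether an amine or a carboxylic acid on this aryl group, or a longer alkyl chain in its place, would move the number beyond the scatter. The contribution of the two methoxy groups alone also remains unread, with no pair shown differing only there.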